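Swapping a benzothiophene for a dichlorophenyl on the core

The compounds below may be only part of what the source reports. "The series", "measured", "known", "first", "only" and "open" are said of these compounds alone.

Measured so far in a functional assay on Jurkat cells for inhibition of nuclear factor NF-kappa-B complex (Homo sapiens); on this read-out higher numbers stand for weaker inhibition and lower numbers for stronger inhibition:
compound 1 `CCOC(=O)c1cnc(C(C)(C)C)nc1NN1C(=O)C=C(C)C1=O` gives 1000 nM
compound 2 `CCOC(=O)c1cnc(-c2cccc(Br)c2)nc1NN1C(=O)C=C(C)C1=O` gives 700 nM
compound 3 `CCOC(=O)c1cnc(-c2cc3ccccc3s2)nc1NN1C(=O)C=C(C)C1=O` gives 4000 nM

Compound 3 stands with the highest number of the three, that is the weakest inhibition in this series: a 4.0-fold higher number from compound 1 to compound 3 (0.60 log units; beyond the scatter) and a 5.7-fold higher number from compound 2 to compound 3 (0.76 log units; beyond the scatter) both lie beyond the scatter. Compound 4 `CCOC(=O)c1cnc(-c2cc(Cl)cc(Cl)c2)nc1NN1C(=O)C=C(C)C1=O` differs from compound 3 by 3,5-dichlorophenyl in place of 1-benzothiophen-2-yl on an aromatic carbon. Among the compounds with values here, the measured step that bears on this is the one from compound 2, which carries a 3-bromophenyl on the same aromatic carbon, to compound 3: a 5.7-fold higher number from compound 2 to compound 3 (0.76 log units; beyond the scatter). Compound 4 again carries a halogenated phenyl on that carbon. The expectation is that much of that step reverses, giving a 4.4-fold lower number from compound 3 to compound 4 (0.65 log units; beyond the scatter) in this assay. The number for compound 4 is therefore estimated at 900 nM, with a likely range from 400 nM to 2500 nM.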

Compound 4, half-maximal inhibitory concentration: 300 nM
The estimate for compound 4 lay 3.0-fold (0.48 log units) above the measured number; the measured number lies below the stated range.
By their numbers in this assay, from the lowest: compound 4; then compounds 2 and 1 (each within the scatter of the next); then compound 3.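

The change gives a 13-fold lower number from compound 3 to compound 4 (1.12 log units; beyond the scatter) in this assay and so does more than recover what the 1-benzothiophen-2-yl group lost. The 3,5-dichlorophenyl group also outdoes both other groups on this aromatic carbon, with a 2.3-fold lower number from compound 2 to compound 4 (0.37 log units; beyond the scatter) and a 3.3-fold lower number from compound 1 to compound 4 (0.52 log units; beyond the scatter) showing that this position can support stronger inhibition than those two groups revealed. No measurement here explains these differences.

As far as these compounds go, whether a phenyl with a single chlorine would keep this gain stays open. So does how an amine or a carboxylic acid on that phenyl would fare.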